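From 4-hydroxyphenyl to 3-methoxyphenyl on compound 3

A few compounds are considered here, and "the series" means these few. Any claim that something is new, unique, unknown or untested is made for them only; others in the source may bear on it.

Compound 1 `CN(C)CCCNc1nc(-c2ccc(F)cc2)nc2ccccc12` gives 63000 nM
Compound 2 `CN(C)CCCNc1nc(-c2ccccc2)nc2ccccc12` gives > 100000 nM, which is a limit of the assay
Compound 3 `CN(C)CCCNc1nc(-c2ccc(O)cc2)nc2ccccc12` gives 65000 nM

All three results come from a toxicity assay on cells (Macrophage, Homo sapiens) for inhibition, read by MTT assay (on this read-out higher numbers stand for weaker inhibition and lower numbers for stronger inhibition), and only two of them are exact numbers. Compound 3 holds one of those two, and they stand level, with a 1.0-fold higher number from compound 1 to compound 3 (0.01 log units; within the scatter) between them.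

The next structure is compound 4 `COc1cccc(-c2nc(NCCCN(C)C)c3ccccc3n2)c1`, which carries 3-methoxyphenyl in place of the 4-hydroxyphenyl of compound 3 on the same aromatic carbon 3-methoxyphenyl in place of 4-hydroxyphenyl on an aromatic carbon and keeps everything else.

Among the compounds with values here, no measured step brings in a methoxy group or shifts a group to another place, so the evidence is indirect. The nearest guides are the three changes made on this same phenyl group. Replacing fluoro with hydroxy gave a 1.0-fold higher number from compound 1 to compound 3 (0.01 log units; within the scatter) and so made no real difference. Two other steps, an at least 1.5-fold higher number from compound 1 to compound 2 (0.20 log units; that floor lies within the scatter) and an at least 1.5-fold lower number from compound 2 to compound 3 (0.18 log units; that floor lies within the scatter), rest on the limit of compound 2, so they give only a floor.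

None of these steps shows a change beyond the scatter. The expected change is therefore small, a 1.1-fold higher number from compound 3 to compound 4 (0.03 log units; within the scatter), and no step beyond the scatter is expected in either direction in this assay for this swap.

Compound 4 is estimated at 70000 nM, with an expected range from 35000 nM to 130000 nM.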

Compound 4, half-maximal inhibitory concentration: 37000 nM
Compound 4: the middle estimate sits 1.9-fold (0.28 log units) above what was measured; the range from low to high includes it.
By their numbers in this assay, from the lowest: compounds 4, 1 and 3 (each within the scatter of the next). At a limit, above all of these: compound 2.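

In this assay, the swap gives a 1.8-fold lower number from compound 3 to compound 4 (0.24 log units; within the scatter), and the change from 4-fluorophenyl gives a 1.7-fold lower number from compound 1 to compound 4 (0.23 log units; within the scatter), so 3-methoxyphenyl at this position, with no hydrogen-bond donor, stands level with both of those earlier groups. Within the data shown here, what is new appears in the comparison with the bare phenyl group: an at least 2.7-fold lower number from compound 2 to compound 4 (0.43 log units; beyond the scatter) is the first step in this set that clears the scatter, so a methoxy group on this phenyl ring can be told apart from hydrogen. The value of compound 2 is a limit and not a number, so this step gives only a floor: the limit of > 100000 nM in this assay, at which 1 of the 4 values shown sits.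

The compounds shown leave open whether the new group or its new place on the phenyl ring matters more in the step from 4-hydroxyphenyl to 3-methoxyphenyl, as both change at once. Also open, going by these compounds, is how an amine, a carboxylic acid or a longer chain such as ethoxy on this phenyl ring would read in this assay.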